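Compound 2 to compound 4: formyl replaces methylsulfonyl

The compounds below may be only part of what the source reports. "The series", "measured", "known", "first", "only" and "open" are said of these compounds alone.

Three compounds sharing one core have been run in an ADME assay on Caco-2 cells (Homo sapiens) for permeability, in the apical to basolateral direction; a lower number here means that the compound crosses the layer more slowly, a higher number that the compound crosses the layer faster. Compound 2 `Cn1nc2c(=O)n(CC3(O)CCN(Cc4ccc(-c5ccco5)cc4Cl)CC3)cnc2c1-c1ccc(CNS(C)(=O)=O)cc1` gives 50 10^-6 cm/s, the highest of the three. Compound 1 `Cn1nc2c(=O)n(CC3(O)CCN(Cc4ccc(-c5ccco5)cc4Cl)CC3)cnc2c1-c1ccc(C2(N)CC2)cc1` gives 1.99 10^-6 cm/s, and compound 3 `Cn1nc2c(=O)n(CC3(O)CCN(Cc4ccc(-c5cccs5)cc4Cl)CC3)cnc2c1-c1ccc(CN)cc1` gives 0.8 10^-6 cm/s, the lowest. For the measured compounds named here, the one measured step among them is a 25-fold higher number from compound 1 to compound 2 (1.40 log units; beyond the scatter), and it is large. The new compound 4 `Cn1nc2c(=O)n(CC3(O)CCN(Cc4ccc(-c5ccco5)cc4Cl)CC3)cnc2c1-c1ccc(CNC=O)cc1` differs from compound 2 in one place: formyl in place of methylsulfonyl on an amine nitrogen. Going by the values given here, this change is smaller than the one in that step: in compound 4 the nitrogen keeps a substituent, and only methylsulfonyl gives way to formyl, so the step from compound 1 to compound 2 bears on it only loosely. Among the compounds with values here, no measured pair matches the change directly. Compound 4 is therefore expected to stay close to compound 2, with a step of a 1.4-fold lower number from compound 2 to compound 4 (0.15 log units; within the scatter) that may well lie within the scatter, perhaps leaning downward. For compound 4 the estimate in this assay is 35 10^-6 cm/s, within a range from 12 10^-6 cm/s to 80 10^-6 cm/s.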

Compound 4, apparent permeability: 0.65 10^-6 cm/s
Compound 4: the middle estimate sits 54-fold (1.73 log units) above what was measured, and the stated range ends above it.
By their numbers in this assay, from the lowest: compounds 4 and 3 (each within the scatter of the next); then compound 1; then compound 2.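

In this assay, the change at the amine nitrogen alone turns out to be decisive: with the nitrogen still substituted and the rest of the molecule unchanged, formyl in place of methylsulfonyl gives a 77-fold lower number from compound 2 to compound 4 (1.89 log units; beyond the scatter). The earlier step had replaced the whole 1-aminocyclopropyl group, whereas this one shows that a substituted nitrogen is not enough for a high number, and there is also a 3.1-fold lower number from compound 1 to compound 4 (0.49 log units; beyond the scatter), a modest step. Of compound 1, compound 2 and compound 4, only the methanesulfonamido compound reaches a high number, and nothing available here explains the size of this step.

On these data alone, it remains open whether the high number depends on the sulfonyl group generally or on methylsulfonyl in particular. An ethylsulfonyl, acetyl or methyl carbamate group on the same nitrogen would help separate these possibilities.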